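From cyclohexyl to iodo: what one step suggests

A few compounds are considered here, and "the series" means these few. Any claim that something is new, unique, unknown or untested is made for them only; others in the source may bear on it.

Measured so far in a functional assay on M21 cells (Homo sapiens) for antiproliferative activity, read by sulforhodamine B assay, with a stated time of 48 h; on this read-out higher numbers stand for weaker inhibition and lower numbers for stronger inhibition
Compound 1 `O=C1NCCN1c1ccc(S(=O)(=O)Nc2ccc(C3CCCCC3)cc2)cc1` gives > 1000 nM
Compound 2 `Cc1ccc(NS(=O)(=O)c2ccc(N3CCNC3=O)cc2)cc1` gives 260 nM

Compound 1 stands at > 1000 nM as a limit of the assay and not as a number. Compound 3 `O=C1NCCN1c1ccc(S(=O)(=O)Nc2ccc(I)cc2)cc1` has yet to be measured. Its difference from compound 1 is a single change (iodo in place of cyclohexyl on an aromatic carbon), namely iodo in place of cyclohexyl on an aromatic carbon, para to a large group.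

Going by the values given here, only one measured step bears on this change. That step is an at least 3.8-fold lower number from compound 1 to compound 2 (0.58 log units; beyond the scatter) and in it methyl takes the place of cyclohexyl on an aromatic carbon. Iodo likewise replaces the cyclohexyl, so a step of similar size towards a lower number in this assay is expected, though it rests on that one step alone. The expectation is therefore (an at least 3.3-fold lower number from compound 1 to compound 3 (0.52 log units; beyond the scatter)), and the size remains uncertain since compound 1 offers only a limit as its starting point. Compound 3 is estimated at 300 nM (expected range 100 nM to 900 nM).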

Compound 3, half-maximal inhibitory concentration: 260 nM
The estimate for compound 3 lay 1.2-fold (0.06 log units) above the measured number; the range from low to high includes it.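

In this assay, a second replacement of the cyclohexyl moves the number the same way as the first, giving an at least 3.8-fold lower number from compound 1 to compound 3 (0.58 log units; beyond the scatter); the drop therefore does not depend on methyl as the entering group. The comparison between the two replacements gives no change at the digits printed from compound 2 to compound 3 (within the scatter), so this assay does not separate iodo from methyl at this place, even though the two are different kinds of group. Compound 1 gives > 1000 nM, which is a limit of the assay and not a number, so both steps away from cyclohexyl have only a lower bound and their true size remains unknown: the limit of > 1000 nM in this assay, at which 1 of the 3 values shown sits.

The compounds shown carry only cyclohexyl, methyl and iodo at this aromatic carbon, so it remains open whether an amine, a carboxylic acid or a longer chain such as n-butyl would match these two values, fall away towards the limit of compound 1 or give a lower number. The three compounds also share the rest of the structure, which leaves open whether the same replacements would have the same effect on a changed core.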